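The source may report more compounds than this note shows. Statements on the series, on what has been measured and on what is new or still open speak of the compounds shown alone.

Measured so far:
- compound 1 `Cc1nc(N2CCC2)nc(OC2CCC2)c1O`: 96%
- compound 2 `Cc1nc(OC2CCC2)nc(N2CCC2)c1O`: 96%

In a functional assay on cells (Lymphocyte, Homo sapiens), read by a luciferase reporter and ATP content, with a stated time of 48 h, tested at 20 uM (a higher number here means a weaker effect of the compound at the concentration tested, a lower number a stronger effect), compound 1 gives 96%. In this assay compound 2 gives 96%. Compound 2 therefore stands level with compound 1 at the digits shown; the two values lie within the scatter of each other, and both read as a weak effect at the concentration tested. Going by the values given here, no pair of measured compounds differing in a single place has been compared in this set, so no measured step exists to lean on.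

Compound 3 `Cc1nc(OC2CCC2)nc(OC2CCC2)c1O` is the next compound. The change from compound 2 is cyclobutyloxy in place of azetidin-1-yl on an aromatic carbon, so compound 3 carries cyclobutyloxy at two places on the shared core instead of one cyclobutyloxy and one azetidin-1-yl. Because compound 2 gives 96% and the swap of one of the two ring substituents between compound 1 and compound 2 left the read-out unchanged, the step of a number 1 percentage points lower from compound 2 to compound 3 (within the scatter) is expected to be small, with no direction beyond the scatter. Compound 3 is estimated to give 95%, in a range from 80% to 106%.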

Compound 3, a percentage reported as activity, at one concentration (the size of the read-out at that concentration, not a potency): 97%
Beside the measured number, compound 3's estimate is 2 percentage points below it, and the stated range covers the measured number.
By their numbers in this assay, from the lowest: compounds 1, 2 and 3 (each within the scatter of the next).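

In this assay, putting cyclobutyloxy in place of azetidin-1-yl on an aromatic carbon gives a number 1 percentage points higher from compound 2 to compound 3 (within the scatter), and the same swap at the other place on the shared core gives a number 1 percentage points higher from compound 1 to compound 3 (within the scatter). Going by these compounds alone, these are the first comparisons here between compounds that differ in one place, and at neither place can the two groups be told apart, so the carbon ortho to a hydroxy group and the second place read alike for this swap, with all three compounds still showing only a weak effect at the concentration tested. Nothing measured here explains this result, and a swap between two such similar four-membered rings probes only a narrow range of groups.

It remains open whether an amine, a carboxylic acid or a longer chain such as n-hexyloxy at either place would give a number clearly lower than those of these compounds. As far as these compounds go, it is equally open whether the hydroxy group or the methyl group on the shared core matters for the read-out, since both stay the same across compound 1, compound 2 and compound 3.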